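The source may hold more compounds than are shown below. What is called first, only, known or untested is meant among the compounds shown, and "the series" means these compounds.

Compound 1 `FC(F)(F)Oc1ccc(Nc2ncnc3nn(C4CCCCC4)cc23)cc1` gives > 10000 nM in an ADME assay on BaF3 cells (Mus musculus) for cytotoxicity (on this read-out higher numbers stand for an effect only at larger amounts of compound and lower numbers for an effect already at smaller amounts), which is a limit of the assay and not a number.
Compound 2 `NC(=O)c1cccc(Oc2cc(Nc3ccc(OC(F)(F)F)cc3)ncn2)c1` gives > 10000 nM in this assay, again a limit.
Compound 3 `NC(=O)c1ccc(-c2cc(Nc3ccc(OC(F)(F)F)cc3)ncn2)cc1` gives > 10000 nM in this assay, likewise a limit.

Compound 1 therefore stands only at a bound, and it shares this position with the other two: the limit of > 10000 nM in this assay, at which 3 of the 3 values shown sit. Within the data shown here, no step between measured compounds is available, so the change to compound 4 `FC(F)(F)Oc1ccc(Nc2ncnc3nn(Cc4ccccc4)cc23)cc1` rests on the structures alone. It is benzyl in place of cyclohexyl on an aromatic nitrogen, in words benzyl in place of cyclohexyl on an aromatic nitrogen. Among the measured compounds shown here, since every compound so far sits at the limit, no step beyond the scatter is expected in this assay, and the expected step is a step that the limit leaves unreadable from compound 1 to compound 4. For compound 4 the expected value is 15000 nM, with a range from 5000 nM to 50000 nM.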

Compound 4, half-maximal effective concentration: > 10000 nM
Compound 4: no number, only a limit; the forecaster's own chance of this, stated with the estimate: 85%; the middle value does not contradict the limit.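

Compound 1 and compound 4 both stand only at a limit in this assay and so no step can be read for benzyl in place of cyclohexyl. The compounds shown leave open at what concentration any of them would show an effect: the limit of > 10000 nM in this assay, at which 4 of the 4 values shown sit.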